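The compounds below may be only part of what the source reports. "The series", "measured", "known", "first", "only" and "open" are said of these compounds alone.

Measured compounds:
- compound 1, `CCCc1cc(C(C)=O)c(O)cc1OCCCCC#N`: 84%
- compound 2, `CCc1cc(C(C)=O)c(O)cc1OCCCCCCC#N`: 103%

Compound 1 gives 84% in an assay on isolated protein for inhibition of leukotriene B4 receptor 1 (Homo sapiens), tested at 10 uM (a lower number here means less inhibition, a higher number more inhibition at the concentration tested (going by the name of the read-out)), the lower of the two numbers shown, and compound 2 gives 103% in this assay, a gap that lies beyond the usual scatter. For the measured compounds named here, the two compounds differ in more than one place, so no single step between them is drawn here.

Compound 3, `CC(=O)c1cc(C=O)c(OCCCCC#N)cc1O`, has not yet been measured in this assay. It differs from compound 1 in one place: formyl in place of propyl on an aromatic carbon. Going by the values given here, with no measured step of this kind among the compounds, the direction of the change is uncertain, but a downward step beyond the scatter in this assay is expected, since the propyl group of compound 1, which gives 84%, is replaced by the smaller formyl group.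

Compound 3 is therefore estimated at 55% in this assay, in the range 25% to 85%, an expected step of a number 29 percentage points lower from compound 1 to compound 3 (beyond the scatter).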

Compound 3, a percentage reported as inhibition, at one concentration (the size of the read-out at that concentration, not a potency): 6%
Compound 3: middle estimate off by 49 percentage points, on the high side, outside the stated range (below it).
By their numbers in this assay, from the lowest: compound 3; then compound 1; then compound 2.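

In this assay, the aromatic carbon para to a hydroxy group proves highly sensitive: formyl in place of propyl gives a number 78 percentage points lower from compound 1 to compound 3 (beyond the scatter) and leaves compound 3 the lowest of the three compounds. Compared with the earlier pair, which differed in more than one place, this is a single-place step, with the acetyl group, the hydroxy group and the nitrile-bearing chain of compound 1 all kept in compound 3. Nothing available accounts for the size of this step.

The compounds shown leave open whether the step comes from the loss of propyl or from the arrival of formyl, as this one change does both. Also open, going by these compounds, is how a hydroxymethyl group, a carboxylic acid, an amine or a butyl chain would fare on this aromatic carbon.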